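Swapping a Phenylethyl Amide for a Pyrrolidinyl Amide

A few compounds are considered here, and "the series" means these few. Any claim that something is new, unique, unknown or untested is made for them only; others in the source may bear on it.

Compound 2 `Cc1nc(-c2ccc(C(F)(F)F)cc2)sc1CNc1ccc([C@H]2C[C@@H]2C(=O)N[C@H](C)c2ccccc2)cc1` shares its core with compound 1 `Cc1nc(-c2ccc(C(F)(F)F)cc2)sc1CNc1ccc(CC(C)C(=O)O)cc1`. Among the measured compounds shown here, in a functional assay on CHO cells for agonist activity at Free fatty acid receptor 1 (Homo sapiens) (on this read-out higher numbers stand for an effect only at larger amounts of compound and lower numbers for an effect already at smaller amounts), compound 2 gives 53.7 nM, the lowest of the two numbers known here, while compound 1 gives 355 nM; the gap between the two lies beyond the scatter. For the measured compounds named here, since the two differ in more than one place, no single step is drawn between them.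

Compound 3 `Cc1nc(-c2ccc(C(F)(F)F)cc2)sc1CNc1ccc([C@H]2C[C@@H]2C(=O)NC2CCNC2)cc1` arises from compound 2 by one change: pyrrolidin-3-yl in place of 1-phenylethyl on an amide-type nitrogen. No step of this kind has been measured among these compounds, so its size rests on expectation alone. The group that leaves carries one six-membered aromatic ring; the pyrrolidin-3-yl that enters brings one hydrogen-bond donor and one hydrogen-bond acceptor, and compound 1, the only other point, carries neither ring. The step of an 8.4-fold higher number from compound 2 to compound 3 (0.92 log units; beyond the scatter) is expected to run toward a higher number, by more than the scatter. Compound 3 is therefore estimated at 450 nM, with a range from 100 nM to 2500 nM.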

Compound 3, half-maximal effective concentration: 204 nM
Compound 3: middle estimate off by 2.2-fold (0.34 log units), on the high side; low and high end bracket the measured number.
By their numbers in this assay, from the lowest: compound 2; then compounds 3 and 1 (each within the scatter of the next).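

In this assay, the amide-type nitrogen now has its first measured step: pyrrolidin-3-yl in place of 1-phenylethyl gives a 3.8-fold higher number from compound 2 to compound 3 (0.58 log units; beyond the scatter), a modest change, so the six-membered aromatic ring of carbon only is not required for an effect at this position, though the number does rise beyond the scatter. The second step, 2-((pyrrolidin-3-yl)carbamoyl)cyclopropyl in place of 2-carboxypropyl on an aromatic carbon, gives a 1.7-fold lower number from compound 1 to compound 3 (0.24 log units; within the scatter) and so lies within the scatter: compound 3, which has no carboxylic acid, cannot be told apart from compound 1, which has one.

The compounds shown leave open whether the step from 1-phenylethyl belongs to the ring nitrogen of pyrrolidin-3-yl or to the loss of the aromatic ring, which a cyclopentyl group on the same nitrogen would help to separate. They also leave open how a carboxylic acid directly on the cyclopropyl ring would read, which would divide the change from compound 1 into its two parts. Nothing measured here gives a reason for either step.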